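Thiosemicarbazide series: piperidinyl to morpholinyl swap on the thiocarbonyl

The source may report more compounds than this note shows. Statements on the series, on what has been measured and on what is new or still open speak of the compounds shown alone.

Measured so far:
compound 1 `Cc1cccc(/C(N)=N/NC(=S)N2CCCCC2)n1`, 27%
compound 2 `N/C(=N\NC(=S)N1CCN(c2ccccn2)CC1)c1ccccn1`, 16.7%
compound 3 `Cc1cccc(/C(N)=N/NC(=S)N2CCCCCC2)n1`, 49.5%

In a functional assay on HeLa cells (Homo sapiens) for cytotoxicity, read by MTT assay, with a stated time of 72 h, tested at 1 uM (on this read-out higher numbers stand for more inhibition of growth at the one concentration tested and lower numbers for less inhibition of growth), compound 1 gives 27% and stands second highest of the three numbers. Its nearest neighbour is compound 2, whose value in this assay is 16.7%, a number lower than that of compound 1 by a gap beyond the usual scatter. Compound 3, which carries the seven-membered ring on the thiocarbonyl carbon, gives 49.5% in this assay, the highest number seen so far and well beyond the scatter above compound 1. Going by the values given here, no single-point steps between measured compounds are available, so nothing can be said about causes.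

Compound 4 `Cc1cccc(/C(N)=N/NC(=S)N2CCOCC2)n1` has not yet been measured. It differs from compound 1 in one place: morpholin-4-yl in place of piperidin-1-yl on a thiocarbonyl carbon.

Among the compounds with values here, with no comparable step, the expectation rests on compound 1 alone. The step of a number 9 percentage points lower from compound 1 to compound 4 (within the scatter) in this assay is expected to be small and downward, near the edge of the scatter rather than clearly beyond it. Compound 4 is therefore estimated at 18% in this assay, within a range from 4% to 34%.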

Compound 4, percent growth inhibition at one concentration: 25.7%
Compound 4: middle estimate off by 7.7 percentage points, on the low side; low and high end bracket the measured number.
By their numbers in this assay, from the lowest: compounds 2, 4 and 1 (each within the scatter of the next, the first and the last beyond it); then compound 3.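

In this assay, morpholin-4-yl in place of piperidin-1-yl on a thiocarbonyl carbon gives a number 1.3 percentage points lower from compound 1 to compound 4 (within the scatter). This is the only single-place step shown in the series, and it indicates that, on the core of compound 1, this position accepts a second ring hetero atom and a hydrogen-bond acceptor without a difference that can be told from the scatter at the single concentration tested. No independent measurement bears on this result, so its origin remains unexplained.

The compounds shown leave open whether piperazin-1-yl or an open-chain dimethylamino group on the same thiocarbonyl carbon would also stay within the scatter of compound 1. They also leave open whether the close match between compound 1 and compound 4 would hold across a full concentration range.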